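Methoxy for Methyl on the Pendant Aryl Ring

This account rests on a few compounds, and the source may have more. Where it says the series, first, only, none or still open, it means among the compounds named here.

Of the compounds shown here, three have so far been measured in an assay on cells for antagonist activity at transient receptor potential cation channel subfamily V member 4 (Rattus norvegicus), read by FLIPR and calcium flux, with a stated time of 10 min; a lower number here means a stronger inhibitor, a higher number a weaker inhibitor. Compound 1 `C[C@H](NC(=O)c1c(CN2CCC(N(C)C)CC2)c(-c2cccc(C(F)(F)F)c2)nc2ccccc12)c1ccccc1` gives 320 nM in this assay. Compound 2 `Cc1ccc(-c2nc3ccccc3c(C(=O)N[C@@H](C)c3ccccc3)c2CN2CCC(N3CCCCC3)CC2)cc1` gives 100 nM, which places it second highest of the three numbers: compound 1 sits higher by a gap beyond the usual scatter, while compound 3 `CCOc1ccc2c(C(=O)NC3(c4ccccc4)CC3)c(CN3CCC(N4CCCCC4)CC3)c(-c3cccc(C(F)(F)F)c3)nc2c1`, with 1.6 nM, sits far lower, again well beyond the scatter. Compound 3 differs from compound 2 at several places at once, so its much lower number cannot be tied to any single change.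

Compound 4 `COc1ccc(-c2nc3ccccc3c(C(=O)N[C@@H](C)c3ccccc3)c2CN2CCC(N3CCCCC3)CC2)cc1` has not yet been measured. It differs from compound 2 in one place only: methoxy in place of methyl on an aromatic carbon. Among the compounds with values here, no measured pair in this set isolates such an exchange, so the expectation rests on the small size of the change. The step is estimated at a 1.1-fold higher number from compound 2 to compound 4 (0.04 log units; within the scatter), that is, nothing beyond the scatter. Compound 4 is accordingly expected to give about 110 nM in this assay, within a range from 40 nM to 300 nM.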

Compound 4, half-maximal inhibitory concentration: 320 nM
Beside the measured number, compound 4's estimate is 2.9-fold (0.46 log units) below it; measured number outside the range, above it.
By their numbers in this assay, from the lowest: compound 3; then compound 2; then compounds 1 and 4 (each within the scatter of the next).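

Within the data shown here, this is the first pair in the set that differs in one place only, and in this assay the change from 4-methylphenyl to 4-methoxyphenyl gives a 3.2-fold higher number from compound 2 to compound 4 (0.51 log units; beyond the scatter). The position para to a large group therefore responds to this exchange, which adds one heavy atom and one hydrogen-bond acceptor, and here methoxy carries the weaker inhibitor. Nothing available bears on why the number rises with this exchange.

The compounds shown leave open how other groups on this aromatic carbon would read, such as a hydroxyl, an ethoxy or a fluorine, and so whether the step follows from the oxygen or from the longer substituent. They also leave open whether the same exchange would give a step of similar size on the other parts of compound 3.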